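The source may report more compounds than this note shows. Statements on the series, on what has been measured and on what is new or still open speak of the compounds shown alone.

Measured in a functional assay on the whole organism with Rattus norvegicus as the target, in the maximal electroshock model; on this read-out higher numbers stand for an effect only at larger amounts of compound and lower numbers for an effect already at smaller amounts:
compound 1 `CNc1ncnc2c1ncn2Cc1ccccc1Cl` gives 6.2 mg/kg
compound 2 `CNc1ncnc2c1ncn2Cc1c(F)cccc1F` gives 2 mg/kg
compound 3 `CCNc1ncnc2c1ncn2Cc1ccccc1F` gives 4.9 mg/kg

Compound 3 stands at the second highest of the three numbers; its gap to compound 1 lies within the scatter, while compound 2 sits at a lower number beyond the scatter. Compound 4 `Fc1ccccc1Cn1cnc2c(NCC3CC3)ncnc21` is not yet measured in this assay. It differs from compound 3 by cyclopropyl in place of methyl on a saturated chain carbon bound to a nitrogen on an aromatic ring. Among the measured compounds shown here, no measured pair carries this change, so no step size for it is known. In this assay a shift not far beyond the scatter is expected, with no clear direction; the estimated step is a 1.1-fold higher number from compound 3 to compound 4 (0.05 log units; within the scatter). For compound 4 a value of 5.5 mg/kg is expected, within a range of 2.5 mg/kg to 12 mg/kg.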

Compound 4, dose for half-maximal effect: 4.3 mg/kg
Compound 4: middle estimate off by 1.3-fold (0.11 log units), on the high side, and the stated range covers the measured number.
By their numbers in this assay, from the lowest: compound 2; then compounds 4, 3 and 1 (each within the scatter of the next).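

In this assay, the chain on the ring nitrogen carries cyclopropyl in place of methyl with a step of a 1.1-fold lower number from compound 3 to compound 4 (0.06 log units; within the scatter), which stays within the scatter. This position therefore accepts an added three-membered ring with no readable change in the dose needed. No measured property bears on this step, so it offers no explanation. Still open, on these data alone, is whether a longer chain, a cyclobutyl group or a terminal amine would also leave the number in place. Also open, as far as these compounds go, is whether cyclopropyl behaves alike on the benzyl group of compound 2.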